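The compounds below may be only part of what the source reports. "The series", "measured", "known", "first", "only" and "open" are said of these compounds alone.

Measured so far:
Compound 1 `CCCCC1([C@@H](O)/C=C/C2[C@H](O)CC(=O)[C@@H]2CCCCCCC(=O)O)CCC1`: 0.03 mg/kg
Compound 2 `CCCCC1([C@H](O)/C=C/C2[C@H](O)CC(=O)[C@@H]2C/C=C\CCCC(=O)O)CCC1`: 0.00106 mg/kg

In a functional assay on the whole organism (strain Hartley) for inhibition, with Cavia porcellus as the target, with stated times of 15 min and 2 min (a higher number here means that more compound is needed for the effect, a lower number that less compound is needed), compound 2 has the lower of the two numbers, and compound 1 stands above it by more than the scatter. Compound 3 `CCCCC1([C@@H](O)/C=C/C2[C@H](O)CC(=O)[C@@H]2C/C=C\CCCC(=O)O)CCC1` awaits measurement. It differs from compound 2 as follows: the two compounds have the same atoms and bonds; at least one stereo element is drawn with a configuration in one of them and without one in the other: 1 of 6 stereo elements differ; a stereocentre at a saturated chain carbon is drawn R in compound 2 and S in compound 3; a stereocentre at a saturated chain carbon is drawn R in compound 2 and S in compound 3. Among the measured compounds shown here, no measured pair shows this change alone. At that carbon compound 3 has the drawing of compound 1, and compound 1 gives 0.03 mg/kg, so a rise beyond the scatter is expected. The estimated step is a 19-fold higher number from compound 2 to compound 3 (1.28 log units; beyond the scatter). For compound 3 the expected value is 0.02 mg/kg, with an estimated range from 0.003 mg/kg to 0.2 mg/kg.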

Compound 3, dose for half-maximal effect: 0.032 mg/kg
Compound 3: the middle estimate sits 1.6-fold (0.20 log units) below what was measured, and the stated range covers the measured number.
By their numbers in this assay, from the lowest: compound 2; then compounds 1 and 3 (each within the scatter of the next).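

In this assay the drawing at this saturated chain carbon alone accounts for a 30-fold higher number from compound 2 to compound 3 (1.48 log units; beyond the scatter) and so the configuration there matters greatly. With this carbon drawn S, 5-carboxypent-1-en-1-yl in place of 5-carboxypentyl gives a 1.1-fold higher number from compound 1 to compound 3 (0.03 log units; within the scatter) and so that chain change shows no effect beyond the scatter. One reservation attaches to the stereo comparison: the fact that one of compounds 2 and 3 is drawn with a defined configuration and the other without, at the place where they differ.

As far as these compounds go, whether 5-carboxypentyl behaves the same with this carbon drawn R remains open. So does the effect of a methoxy group or an amine in place of the hydroxyl at this carbon.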